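A few compounds are considered here, and "the series" means these few. Any claim that something is new, unique, unknown or untested is made for them only; others in the source may bear on it.

In an ADME assay on HUVEC cells (Homo sapiens) for cytotoxicity, read by MTT assay, with a stated time of 24 h (on this read-out higher numbers stand for weaker inhibition and lower numbers for stronger inhibition), compound 1 `Cc1ccc(/C=C2\CC[C@H]3C(C)(C)CCC[C@]3(C)[C@H]2CCC(C)CC(=O)O)cc1` gives > 200000 nM, which is a limit and not a number. Compound 2 `COc1ccc(/C=C2\CC[C@H]3C(C)(C)CCC[C@]3(C)[C@H]2CCC(C)CC(=O)O)cc1OC` gives > 200000 nM, which is also a limit. Compound 2 therefore stands on (the limit of > 200000 nM in this assay, at which 2 of the 2 values shown sit).

Compound 3 `CC(CC[C@H]1/C(=C/c2ccc(I)cc2)CC[C@H]2C(C)(C)CCC[C@]12C)CC(=O)O` differs from compound 2 as follows: 4-iodophenyl in place of 3,4-dimethoxyphenyl on a double-bonded chain carbon bound to a double-bonded ring carbon. In words, 4-iodophenyl replaces 3,4-dimethoxyphenyl on a double-bonded chain carbon bound to a double-bonded ring carbon.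

For the measured compounds named here, the only measured step bearing on this change is a step that the two limits leave unreadable from compound 1 to compound 2. It gives no size to carry forward, so no step beyond the scatter is expected in this assay, and no direction is expected either. The step expected is a number no higher from compound 2 to compound 3 (the limit leaves the size open). The estimate for compound 3 is 200000 nM, with an expected range of 100000 nM to 400000 nM, and a reading at the limit is the likeliest outcome.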

Compound 3, half-maximal inhibitory concentration: 194000 nM
Compound 3: the middle estimate sits 1.0-fold (0.01 log units) above what was measured; low and high end bracket the measured number.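

In this assay, 4-iodophenyl on a double-bonded chain carbon bound to a double-bonded ring carbon gives the only reading shown that is a number and not a limit: compound 3 gives 194000 nM. Replacing 3,4-dimethoxyphenyl gives an at least 1.0-fold lower number from compound 2 to compound 3 (0.01 log units; that floor lies within the scatter), and iodo in place of methyl on an aromatic carbon gives an at least 1.0-fold lower number from compound 1 to compound 3 (0.01 log units; that floor lies within the scatter). The step between compound 1 and compound 2 cannot be read, and the limit still describes most of the series: the limit of > 200000 nM in this assay, at which 2 of the 3 values shown sit.

On these data alone, how far the true values of compound 1 and compound 2 lie from the value of compound 3 remains open, so the real size of both steps is unknown. Also open, as far as these compounds go, is whether an amine on the phenyl ring would bring the reading clearly down.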